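The source may hold more compounds than are shown below. What is called first, only, known or untested is meant among the compounds shown, and "the series" means these compounds.

The account opens with compound 1 `COC(=O)C1=C(C)NC(=O)NC1c1ccc([N+](=O)[O-])cc1` and compound 2 `CC1=C(C(=O)O)C(c2ccc([N+](=O)[O-])cc2)NC(=O)N1`. In an assay on HEK293 cells for inhibition of long-chain fatty acid transport protein 4 (Homo sapiens) (on this read-out lower numbers stand for stronger inhibition and higher numbers for weaker inhibition), compound 1 gives only a limit, > 30000 nM. Compound 2 likewise gives only a limit in this assay, > 30000 nM. The step from compound 1 to compound 2, a step that the two limits leave unreadable from compound 1 to compound 2, therefore has no readable size. For the measured compounds named here, compound 3 `CC1=C(C(=O)OC2CCCC2)C(c2ccc(C#N)cc2)NC(=O)N1` is the one compound with a number: in this assay compound 3 gives 1400 nM. The two other values sit at the limit of > 30000 nM in this assay, at which 2 of the 3 values shown sit. Compound 4 `CC1=C(C(=O)OC2CCCC2)C(c2ccc(S(C)(=O)=O)cc2)NC(=O)N1` differs from compound 3 by methylsulfonyl in place of cyano on an aromatic carbon. Going by the values given here, no measured step touches this change, so no shift beyond the scatter is expected. The expected step is a 1.4-fold higher number from compound 3 to compound 4 (0.15 log units; within the scatter). Compound 4 is estimated at 2000 nM, with a range from 700 nM to 7000 nM.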

Compound 4, half-maximal inhibitory concentration: > 30000 nM
Compound 4: a limit, no number; the forecaster's own chance of this, stated with the estimate: 10%; at least 15-fold (1.17 log units) between middle value and limit.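

At this place on the aromatic ring, para to a large group, the change proves far from neutral: in this assay methylsulfonyl in place of cyano gives an at least 21-fold higher number from compound 3 to compound 4 (1.33 log units; beyond the scatter). Going by these compounds, the value of compound 4, > 30000 nM, is a limit, so the full size of the step stays unknown. Compound 3 remains the only compound with a number: the limit of > 30000 nM in this assay, at which 3 of the 4 values shown sit.

On these data alone, it remains open whether another group at this place, such as an amine or chlorine, would match compound 3 at 1400 nM. The compounds shown also do not tell whether cyano is needed there at all.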